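The compounds below may be only part of what the source reports. "The series", "measured", "known", "first", "only" and "open" are said of these compounds alone.

Compound 1 `O=C1O[C@@H](CN2CCCCC2)CN1c1ccc(-n2cc(-c3ccccn3)cn2)c(F)c1` is one of two compounds that have been measured in an ADME assay on L02 cells (Homo sapiens) for cytotoxicity, read by MTT assay, with a stated time of 48 h; a lower number here means a stronger inhibitor, a higher number a weaker inhibitor. In this assay compound 1 gives > 400 ug/mL, which is a limit of the assay and not a number. Compound 2 `COC[C@H]1CN(c2ccc(-n3cc(-c4ccccn4)cn3)c(F)c2)C(=O)O1` differs from compound 1 by a methoxy in place of piperidin-1-yl on a saturated chain carbon bound to a saturated ring carbon. In this assay compound 2 gives > 400 ug/mL, likewise a limit. The step that the two limits leave unreadable from compound 1 to compound 2 can therefore not be read. Where compound 1 stands is known only as a limit, and the one other value shown is a limit as well: the limit of > 400 ug/mL in this assay, at which 2 of the 2 values shown sit. Compound 3 `O=C1O[C@@H](Cn2ccnn2)CN1c1ccc(-n2cc(-c3ccccn3)cn2)c(F)c1` differs from compound 1 by 1H-1,2,3-triazol-1-yl in place of piperidin-1-yl on a saturated chain carbon bound to a saturated ring carbon. No measured step bears directly on this change; the one step shown, from compound 1 to compound 2, is unreadable in size. Compound 3 is expected to sit in the same region as compound 1, with the step that the limit leaves unreadable from compound 1 to compound 3 expected to be none beyond the scatter, and the measurement is expected most likely to come back as a limit. The estimate for compound 3 in this assay is 450 ug/mL, between 250 ug/mL and 900 ug/mL.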

Compound 3, half-maximal inhibitory concentration: 49 ug/mL
Beside the measured number, compound 3's estimate is 9.2-fold (0.96 log units) above it; the measured number lies below the stated range.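

Until this result, the place on a saturated chain carbon bound to a saturated ring carbon had yielded no readable number, since both earlier compounds stopped at the same limit: the limit of > 400 ug/mL in this assay, at which 2 of the 3 values shown sit.

In this assay, among these compounds, 1H-1,2,3-triazol-1-yl is the first group at this place to bring a measured number, with an at least 8.1-fold lower number from compound 1 to compound 3 (0.91 log units; beyond the scatter), and the comparison with methoxy gives an at least 8.1-fold lower number from compound 2 to compound 3 (0.91 log units; beyond the scatter). The rest of the structure is shared by these compounds, so these steps show that a change at this one place is enough to move the read-out beyond the scatter, from either of two quite different groups, piperidin-1-yl and methoxy. Going by these compounds, their full size stays open, as each starts from a limit.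

The step from compound 1 to compound 2 cannot be read, so nothing orders piperidin-1-yl and methoxy against each other. The compounds shown also leave open whether the step follows the aromatic ring or the ring nitrogens of 1H-1,2,3-triazol-1-yl, a question on which a pyrazole or an open-chain amine at this place would bear.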